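Three analogues measured, a benzyl variant still to come

The source may report more compounds than this note shows. Statements on the series, on what has been measured and on what is new or still open speak of the compounds shown alone.

Measured so far:
compound 1, `N#CC1=C(N)N(c2ccc(S(N)(=O)=O)cc2)C2=C(C(=O)CCC2)C1c1ccccc1`, 30%
compound 2, `N#CC1=C(N)N(c2ccc(S(N)(=O)=O)cc2)C2=C(C(=O)CCC2)C1/C=C/c1ccccc1`, 10%
compound 3, `COc1ccccc1C1C(C#N)=C(N)N(c2ccc(S(N)(=O)=O)cc2)C2=C1C(=O)CCC2`, 0%

In a functional assay on Ehrlich cells (Mus musculus) for antiproliferative activity, read by trypan blue exclusion, with a stated time of 2 h, tested at 25 ug/mL (a higher number here means a stronger effect of the compound at the concentration tested, a lower number a weaker effect), compound 1 gives 30%, compound 2 gives 10% and compound 3 gives 0%. On these numbers compound 3 sits at the bottom: the difference from compound 2 is a number 10 percentage points lower from compound 2 to compound 3 (within the scatter), whereas a number 30 percentage points lower from compound 1 to compound 3 (beyond the scatter) and a number 20 percentage points lower from compound 1 to compound 2 (beyond the scatter) both lie beyond the scatter. Compound 4, `COc1cc(CC2C(C#N)=C(N)N(c3ccc(S(N)(=O)=O)cc3)C3=C2C(=O)CCC3)ccc1O`, is not yet measured. Its change from compound 3 is 4-hydroxy-3-methoxybenzyl in place of 2-methoxyphenyl on a saturated ring carbon. Among the compounds with values here, no measured step swaps in a benzyl group, so none bears on it directly; the two steps that alter the group on the saturated ring carbon, a number 20 percentage points lower from compound 1 to compound 2 (beyond the scatter) and a number 10 percentage points lower from compound 2 to compound 3 (within the scatter), went down or stayed flat, and compound 3 already reads at the floor of this assay. A number near the floor is therefore expected for compound 4, with a number 10 percentage points higher from compound 3 to compound 4 (within the scatter) as the estimated step, which is within the scatter. The estimate for compound 4 in this assay is 10%, ranging from 0% to 30%.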

Compound 4, a percentage reported as activity, at one concentration (the size of the read-out at that concentration, not a potency): 50%
Estimate against measurement, compound 4: 40 percentage points below, outside the stated range (above it).
By their numbers in this assay, from the lowest: compounds 3 and 2 (each within the scatter of the next); then compound 1; then compound 4.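

In this assay, the group on the saturated ring carbon proved able to raise the read-out as well as lower it: a number 50 percentage points higher from compound 3 to compound 4 (beyond the scatter), a number 40 percentage points higher from compound 2 to compound 4 (beyond the scatter) and a number 20 percentage points higher from compound 1 to compound 4 (beyond the scatter). The earlier changes at this position had only gone down or stayed flat, and 4-hydroxy-3-methoxybenzyl is the only group shown that stands above the phenyl of compound 1. No measurement here explains this rise.

The compounds shown leave open which feature of the entering group carries the gain, since compound 4 adds the benzyl link and the hydroxy group in a single change. On these data alone, a plain benzyl group and a phenyl bearing only a hydroxy group would separate the two, and whether the gain survives with a carboxylic acid in place of that hydroxy group also remains open.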